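This account rests on a few compounds, and the source may have more. Where it says the series, first, only, none or still open, it means among the compounds named here.

Measured so far in a functional assay on HT-29 cells (Homo sapiens) for inhibition, read by sulforhodamine B assay, with a stated time of 48 h, tested at 100 uM; on this read-out lower numbers stand for a stronger effect and higher numbers for a weaker effect at the one concentration tested:

compound 1, `O=C(Nc1cccc(-n2cc(-c3ccncc3)c(-c3cc(O)cc(Cl)c3)n2)c1)Nc1ccc(Cl)c(C(F)(F)F)c1`, gives -88%
compound 2, `O=C(Nc1cccc(-n2cc(-c3ccncc3)c(-c3cc(O)cc(Cl)c3)n2)c1)Nc1ccc(Cl)c(Cl)c1`, gives -70%

Compound 1 stands lowest of the two numbers, which on this read-out means the stronger effect at the single concentration tested. For the measured compounds named here, the one measured step, a number 18 percentage points higher from compound 1 to compound 2 (beyond the scatter), swaps a group on the outer aromatic ring of the urea part and is modest in size.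

Compound 3, `COc1cc(Cl)cc(-c2nn(-c3cccc(NC(=O)Nc4ccc(Cl)c(C(F)(F)F)c4)c3)cc2-c2ccncc2)c1`, differs from compound 1 in one place: methyl in place of hydrogen on an oxygen on an aromatic ring. Going by the values given here, no measured step touches this oxygen, so the step from compound 1 to compound 2 offers no direct guide; it only shows that one-group changes elsewhere moved the read-out modestly. On that basis, compound 3 is expected to stay close to compound 1, with a step of a number 10 percentage points higher from compound 1 to compound 3 (within the scatter) that may be within the scatter. The estimate for compound 3 is -78%, with a range from -100% to -45%.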

Compound 3, a percentage reported as activity, at one concentration (the size of the read-out at that concentration, not a potency): -84%
The estimate for compound 3 lay 6 percentage points above the measured number, within the range that was stated.
By their numbers in this assay, from the lowest: compounds 1 and 3 (each within the scatter of the next); then compound 2.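

Replacing hydroxy with methoxy on the aromatic ring gives, in this assay, a number 4 percentage points higher from compound 1 to compound 3 (within the scatter), so the two compounds cannot be told apart at the single concentration tested. The hydrogen on this oxygen is therefore not required for a strong read-out here, and this position accepts a methyl group without a change that stands out from the usual variation between repeats. No measured property of these compounds offers an explanation for this result.

The compounds shown leave open whether this position would accept an ethoxy group or a longer chain on the oxygen, or an amine in place of the oxygen. From the compounds shown here alone, a reading at one concentration is also not a potency, so whether compound 1 and compound 3 would still match at lower concentrations remains unknown.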